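The source may report more compounds than this note shows. Statements on the series, on what has been measured and on what is new or still open speak of the compounds shown alone.

Measured compounds:
compound 1 `COC(=O)c1cccc(-c2cnc(C(=O)CCCCCCc3ccccc3)o2)c1` — 12 nM
compound 2 `Cc1ccc(-c2cnc(C(=O)CCCCCCc3ccccc3)o2)nc1` — 2.8 nM

In an assay (Rattus norvegicus) for inhibition of Fatty-acid amide hydrolase 1 (Homo sapiens) (a lower number here means a stronger inhibitor, a higher number a weaker inhibitor), compound 2 gives the lowest of the two numbers; compound 1, its nearest neighbour, sits beyond the scatter above it. Compound 3 `O=C(CCCCCCc1ccccc1)c1ncc(-c2cc(=O)[nH]c(=O)[nH]2)o1` is not yet measured. Its change from compound 2 is a group of 8 heavy atoms (4 carbon, 2 nitrogen, 2 oxygen; one six-membered aromatic ring with 2 hetero atoms) in place of a group of 7 heavy atoms (6 carbon, 1 nitrogen; one six-membered aromatic ring with 1 hetero atom), on an aromatic carbon. Going by the values given here, no measured pair shows a step of this kind, so the size is uncertain. Compound 3 is expected to be a weaker inhibitor, with a step of a 7.1-fold higher number from compound 2 to compound 3 (0.85 log units; beyond the scatter) in this assay. The estimate for compound 3 is 20 nM, between 5 nM and 100 nM.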

Compound 3, inhibition constant: 12 nM
Compound 3: the middle estimate sits 1.7-fold (0.22 log units) above what was measured, and the stated range covers the measured number.
By their numbers in this assay, from the lowest: compound 2; then compounds 1 and 3 (each within the scatter of the next).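

In this assay the step of a 4.3-fold higher number from compound 2 to compound 3 (0.63 log units; beyond the scatter) is modest, and it shows that this aromatic carbon next to the ring oxygen can carry a ring with hydrogen-bond donors, which neither earlier compound had, and still give compound 3 at 12 nM in this assay. No measurement given here bears on the reason for this step. The compounds shown leave open whether the donors or the rest of the new ring account for the step. A plain phenyl, or a carboxylic acid on the phenyl ring in place of the methyl ester of compound 1, would test this position further.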